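From Butyl to Butoxy on an Aromatic Ring

The source may hold more compounds than are shown below. What is called first, only, known or untested is meant among the compounds shown, and "the series" means these compounds.

Of the compounds shown here, two sharing one core have been measured so far in a functional assay on brain (Rattus norvegicus, strain Wistar) for inhibition; on this read-out lower numbers stand for stronger inhibition and higher numbers for weaker inhibition. Compound 1 (`Cc1[nH]c(=O)n(C2CCCCC2)c1-c1ccccc1`) gives 47600 nM, and compound 2 (`CCCCc1ccc(-c2c(C)[nH]c(=O)n2C2CCCCC2)cc1`) gives 27100 nM. Among the measured compounds shown here, these are the only two numbers available, and they lie within the scatter of each other, so compound 2 cannot be separated from compound 1 on these data.

Compound 3 (`CCCCOc1ccc(-c2c(C)[nH]c(=O)n2C2CCCCC2)cc1`) has not been measured yet. It carries one structural change, (butoxy in place of butyl on an aromatic carbon), which places butoxy in place of butyl on an aromatic carbon, para to a large group. For the measured compounds named here, no measured compound contains butoxy, so the data offer no direct test of this change.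

Going by the values given here, only one measured step bears on it: a 1.8-fold lower number from compound 1 to compound 2 (0.24 log units; within the scatter). With a step that small when butyl replaced hydrogen on an aromatic carbon, no step beyond the scatter is expected in this assay. The expected step is a 1.0-fold lower number from compound 2 to compound 3 (0.02 log units; within the scatter). For compound 3 the estimate is 26000 nM, with an expected range of 11000 nM to 60000 nM.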

Compound 3, half-maximal inhibitory concentration: 13900 nM
Compound 3: middle estimate off by 1.9-fold (0.27 log units), on the high side; the range from low to high includes it.
By their numbers in this assay, from the lowest: compounds 3, 2 and 1 (each within the scatter of the next, the first and the last beyond it).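

In this assay, this position on the aromatic ring now gives a step that can be read: replacing the hydrogen there with butoxy gives a 3.4-fold lower number from compound 1 to compound 3 (0.53 log units; beyond the scatter) and so clears the usual spread of repeat measurements, although the size of the step is only modest. Butoxy in place of butyl, which adds an oxygen and a hydrogen-bond acceptor to the chain, gives a 1.9-fold lower number from compound 2 to compound 3 (0.29 log units; within the scatter) and leaves the two chains inseparable on these numbers, so the data do not show that the oxygen matters here. Nothing measured alongside these compounds explains the difference between butoxy and hydrogen at this position.

The compounds shown leave open whether a longer chain, such as hexyloxy, or a shorter one, such as methoxy, on the same aromatic carbon would give a larger step than butoxy does. Among the compounds shown here, they also leave open how the number would respond to an amine or a carboxylic acid at the end of the chain, since every substituent at this position so far is either hydrogen or an uncharged four-carbon chain.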